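Swapping Methoxy for Nitro on a Weakly Cytotoxic Core

The compounds below may be only part of what the source reports. "The series", "measured", "known", "first", "only" and "open" are said of these compounds alone.

Among the measured compounds shown here, compound 1 `COc1ccc(-c2c(C#N)c(N)n(/N=C(/C)c3ccc(NS(=O)(=O)c4ccc(C)cc4)cc3)c(=O)c2C#N)cc1` is the only compound with a number in hand: in a functional assay on HepG2 cells (Homo sapiens) for cytotoxicity, read by sulforhodamine B assay, with a stated time of 48 h (on this read-out lower numbers stand for stronger inhibition and higher numbers for weaker inhibition), compound 1 gives 31800 nM. Compound 2 `Cc1ccc(S(=O)(=O)Nc2ccc(-c3cc(-c4ccc([N+](=O)[O-])cc4)n(C(N)=S)n3)cc2)cc1`, built on a different core, gives "not active" (no number reported) in this assay. Compound 3 `C/C(=N/n1c(N)c(C#N)c(-c2ccc([N+](=O)[O-])cc2)c(C#N)c1=O)c1ccc(NS(=O)(=O)c2ccc(C)cc2)cc1` differs from compound 1 by nitro in place of methoxy on an aromatic carbon, that is 4-methoxyphenyl to 4-nitrophenyl. For the measured compounds named here, no measured pair shows this change, so the step of a 1.1-fold lower number from compound 1 to compound 3 (0.03 log units; within the scatter) is an estimate, expected to stay within the usual scatter. Compound 3 is therefore expected to come near 30000 nM, between 10000 nM and 100000 nM.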

Compound 3, half-maximal inhibitory concentration: 31500 nM
Compound 3: middle estimate off by 1.1-fold (0.02 log units), on the low side; measured number inside the range.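

Among the compounds shown here, the step of a 1.0-fold lower number from compound 1 to compound 3 (0.00 log units; within the scatter) in this assay gives the first measured reading at this position, on an aromatic carbon para to a large group. On the shared core, 4-methoxyphenyl and 4-nitrophenyl cannot be told apart on this read-out, so this one exchange leaves cytotoxicity weak. Nothing on hand offers an explanation for this result.

From the compounds shown here alone, whether an amine or a carboxylic acid at this position would give a different number remains open. So does whether any group here can move the value beyond the scatter.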